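A few compounds are considered here, and "the series" means these few. Any claim that something is new, unique, unknown or untested is made for them only; others in the source may bear on it.

Among the measured compounds shown here, in an ADME assay on J774 cells (Mus musculus) for cytotoxicity (on this read-out lower numbers stand for an effect already at smaller amounts and higher numbers for an effect only at larger amounts of compound), compound 2 `Cc1ccc2[nH]c(C)c(Br)c(=O)c2c1` gives 19600 nM, the only actual number so far. Compound 1 `COc1ccc2[nH]c(C)c(Br)c(=O)c2c1` gives > 37300 nM, which is a limit of the assay. Compound 3 `Cc1[nH]c2ccc(F)cc2c(=O)c1Br` carries fluoro in place of methyl on an aromatic carbon. For the measured compounds named here, the one measured step on that carbon is an at least 1.9-fold lower number from compound 1 to compound 2 (0.27 log units; that floor lies within the scatter), so no step beyond the scatter is expected in this assay. The estimate means an expected 1.3-fold higher number from compound 2 to compound 3 (0.11 log units; within the scatter). For compound 3 the expected value is 25000 nM, with an estimated range of 10000 nM to 50000 nM.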

Compound 3, half-maximal effective concentration: > 39100 nM
Compound 3 gave a limit, no number; the forecaster's own chance of this, stated with the estimate: 35%; middle value at least 1.5-fold (0.19 log units) away from the limit.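

In this assay, fluoro in place of methyl on this aromatic carbon gives an at least 1.9-fold higher number from compound 2 to compound 3 (0.29 log units; that floor lies within the scatter). Like the methoxy-to-methyl step, this change therefore shows no step proven beyond the scatter, and compound 2 remains the only compound with an actual number. The step from compound 1 to compound 3 cannot be read, as both values are limits.

As far as these compounds go, how far compound 1 and compound 3 truly lie from compound 2 stays open. Also open, from the compounds shown here alone, is whether an amine or a carboxylic acid on this carbon would give a number in this assay.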